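A Hydroxyphenyl Swap on a Cytotoxicity-Capped Core

The source may report more compounds than this note shows. Statements on the series, on what has been measured and on what is new or still open speak of the compounds shown alone.

Of the compounds shown here, three that share one core have been tested in an ADME assay on Vero cells (Chlorocebus sabaeus) for cytotoxicity; a lower number here means that less compound is tolerated, a higher number that more compound is tolerated. Compound 1 `COc1ccc(-c2nc3c(NC4CCCC4)cccn3c2-c2ccnc(NC3CCCC3)n2)cc1` gives > 10000 nM, which is a limit of the assay and not a number. Compound 2 `Oc1ccc(-c2nc3c(NC4CCCC4)cccn3c2-c2ccnc(NC3CCCC3)n2)cc1` gives > 40000 nM, again a limit. Compound 3 `c1cc(NC2CCCC2)c2nc(-c3ccc(OCC4CC4)cc3)c(-c3ccnc(NC4CCCC4)n3)n2c1` gives > 40000 nM, also a limit. Among the compounds with values here, compound 3 therefore stands at a limit, as do the two other values, and no compound can be called more or less tolerated than another. The steps among them, a step that the two limits leave unreadable from compound 1 to compound 2, a step that the two limits leave unreadable from compound 1 to compound 3 and a step that the two limits leave unreadable from compound 2 to compound 3, carry no readable size because the limit of > 10000 nM in this assay, at which 1 of the 3 values shown sits, and the limit of > 40000 nM in this assay, at which 2 of the 3 values shown sit, cap every value.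

Compound 4 `Oc1cccc(-c2nc3c(NC4CCCC4)cccn3c2-c2ccnc(NC3CCCC3)n2)c1` is the untested one; it differs from compound 3 by 3-hydroxyphenyl in place of 4-(cyclopropylmethoxy)phenyl on an aromatic carbon. Given (the limit of > 40000 nM in this assay, at which 2 of the 3 values shown sit), where a hydroxyl-bearing compound already sits, the expected step is a step that the limit leaves unreadable from compound 3 to compound 4, nothing beyond the scatter. The estimate for compound 4 in this assay is 50000 nM, with a range from 20000 nM to 120000 nM, and it is expected most likely to be reported once more as a limit.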

Compound 4, half-maximal cytotoxic concentration: > 40000 nM
Compound 4 was reported as a limit (the forecaster's own chance of this, stated with the estimate: 80%); the middle value is on the limit's open side.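

In this assay compound 4 is again reported as a limit, so no step to it from compound 1, compound 2 or compound 3 can be read: the limit of > 40000 nM in this assay, at which 3 of the 4 values shown sit.

The compounds shown leave open at what concentration any of the four harms the cells, and whether 3-hydroxyphenyl in place of 4-hydroxyphenyl changes that.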